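Arylpiperazine thiophene series: halogen pattern on the aryl piperazine

A few compounds are considered here, and "the series" means these few. Any claim that something is new, unique, unknown or untested is made for them only; others in the source may bear on it.

Measured compounds in a functional assay on CHO cells with adenosine receptor A1 (Homo sapiens) as the target, read by cAMP accumulation and immunoassay, with a stated time of 6 min, tested at 0.1 uM; on this read-out higher numbers stand for a weaker effect at the one concentration tested and lower numbers for a stronger effect:
compound 1 `Nc1scc(CN2CCN(c3c(F)cccc3F)CC2)c1C(=O)c1ccc(Cl)cc1` gives -23%
compound 2 `Nc1scc(CN2CCN(c3cc(F)ccc3F)CC2)c1C(=O)c1ccc(Cl)cc1` gives -13%
compound 3 `Nc1scc(CN2CCN(c3c(F)cc(F)cc3F)CC2)c1C(=O)c1ccc(Cl)cc1` gives -3.9%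

Compound 3 is separated from compound 1 by a number 19.1 percentage points higher from compound 1 to compound 3 (beyond the scatter), while its gap to compound 2, a number 9.1 percentage points higher from compound 2 to compound 3 (within the scatter), is within the scatter; the move from compound 1 to compound 2, a number 10 percentage points higher from compound 1 to compound 2 (within the scatter), is likewise within the scatter. Compound 4 `Nc1scc(CN2CCN(c3cc(Cl)ccc3Cl)CC2)c1C(=O)c1ccc(Cl)cc1` is not yet measured. Its change from compound 3 is 2,5-dichlorophenyl in place of 2,4,6-trifluorophenyl on an amine nitrogen in a ring. Among the compounds with values here, compound 2 carries the same substitution pattern with fluorine instead of chlorine, and no measured step speaks to swapping chlorine for fluorine here, so compound 4 is expected to sit near compound 2, giving a number 6.1 percentage points lower from compound 3 to compound 4 (within the scatter), a step within the scatter. Compound 4 is estimated at -10%, between -30% and 10%.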

Compound 4, a percentage reported as activity, at one concentration (the size of the read-out at that concentration, not a potency): -6.2%
For compound 4 the middle estimate is 3.8 percentage points below the measured one; the measured number falls inside the stated range.
By their numbers in this assay, from the lowest: compounds 1, 2, 4 and 3 (each within the scatter of the next, the first and the last beyond it).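

Within the data shown here, the 2,5-dichlorophenyl group is the first chlorine-bearing group at this amine nitrogen, and exchanging the halogen of 2,5-difluorophenyl gives a number 6.8 percentage points higher from compound 2 to compound 4 (within the scatter) with no separation from its fluorine counterpart. Replacing 2,4,6-trifluorophenyl gives a number 2.3 percentage points lower from compound 3 to compound 4 (within the scatter) and also shows no separation. Only the comparison with 2,6-difluorophenyl gives a number 16.8 percentage points higher from compound 1 to compound 4 (beyond the scatter) and so exceeds the scatter. No available evidence accounts for these differences.

Open: whether methoxy or methyl groups on this aryl ring, or an unsubstituted phenyl, would stay within this range of values.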